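The source may report more compounds than this note shows. Statements on the series, on what has been measured and on what is new or still open speak of the compounds shown alone.

Working notes on the series. In an ADME assay on Caco-2 cells (Homo sapiens) for permeability, read by LC-MS, in the apical to basolateral direction, with a stated time of 60 min, at pH 6.5 (a lower number here means that the compound crosses the layer more slowly, a higher number that the compound crosses the layer faster), compound 2 (`CC(C)(C)C[C@@H](O)C(=O)N1N=CC[C@H]1C(=O)NCc1cc(Cl)ccc1-n1cnnn1`) gives 24 10^-6 cm/s. This is level with compound 3 (`CC(C)(C)C[C@@H](O)C(=O)N1[C@@H]2C[C@@H]2C[C@H]1C(=O)NCc1cc(Cl)ccc1-n1cnnn1`) at 24 10^-6 cm/s, within the scatter. Compound 1 (`CC(C)(C)[C@@H](O)C(=O)N1CCS[C@H]1C(=O)NCc1cc(Cl)ccc1-n1cnnn1`) gives 5.2 10^-6 cm/s, a lower number than compound 2 and beyond the scatter. Compound 2 therefore sits at the upper end of the numbers in hand, together with compound 3.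

The next compound is compound 4 (`O=C(NCc1cc(Cl)ccc1-n1cnnn1)[C@@H]1CC=NN1C(=O)[C@H](O)C1CCCCC1`), which differs from compound 2 in one place: cyclohexyl in place of neopentyl on a saturated chain carbon bound to a carbonyl carbon and an oxygen on a saturated carbon. Cyclohexyl stands in place of neopentyl on a saturated chain carbon bound to a carbonyl carbon and an oxygen on a saturated carbon.

Going by the values given here, no two measured compounds differ in one place only. Among the compounds with values here, the data therefore contain no measured step for this change or any other. With compound 2 at 24 10^-6 cm/s as the reference, no step beyond the scatter is expected in this assay. The estimated step, a 1.2-fold lower number from compound 2 to compound 4 (0.08 log units; within the scatter), is expected to stay within the scatter. The range is kept wide on the low side, as the measured numbers reach down to compound 1 at 5.2 10^-6 cm/s. For compound 4 the estimated value is 20 10^-6 cm/s, with an expected range from 9 10^-6 cm/s to 42 10^-6 cm/s.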

Compound 4, apparent permeability: 19 10^-6 cm/s
Estimate against measurement, compound 4: 1.1-fold (0.02 log units) above; the measured number falls inside the stated range.
By their numbers in this assay, from the lowest: compound 1; then compounds 4, 2 and 3 (each within the scatter of the next).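

Going by these compounds alone, compound 4 supplies the first step that can be read in one place: in this assay, cyclohexyl in place of neopentyl on a saturated chain carbon bound to a carbonyl carbon and an oxygen on a saturated carbon gives a 1.3-fold lower number from compound 2 to compound 4 (0.10 log units; within the scatter) and so no change that can be told from the scatter. At this position, then, an open chain of 5 heavy atoms and a six-membered non-aromatic ring of carbon only are interchangeable in this read-out, so this one exchange of a carbon-only group, with no hydrogen-bond donors or acceptors on either side, leaves the number in place. All other pairs among the compounds shown differ in more than one place, so their steps cannot be read, and nothing measured here accounts for the result.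

As far as these compounds go, whether the number holds with an amine, a carboxylic acid or a phenyl ring on this carbon remains open, since both groups compared here are saturated and made of carbon only. Also open, from the compounds shown here alone, is whether the same exchange would stay within the scatter on the cores of compound 1 or compound 3.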